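A few compounds are considered here, and "the series" means these few. Any claim that something is new, unique, unknown or untested is made for them only; others in the source may bear on it.

For the measured compounds named here, compound 1, whose structure is `CCN(CCCCOc1ccc(C(=O)/C=C/c2ccc(N(C)C)cc2)c(O)c1)Cc1ccccc1`, is the weakest of the three compounds measured so far in an assay on isolated protein for inhibition of Amine oxidase [flavin-containing] B (Homo sapiens) (a higher number here means a weaker inhibitor, a lower number a stronger inhibitor), giving 8900 nM. Compound 2, `CCN(CCCCOc1ccc(C(=O)/C=C/c2ccc(N(C)C)cc2)c(O)c1)Cc1ccc(N(C)C)cc1`, carries one extra group, (dimethylamino in place of hydrogen on an aromatic carbon), and in this assay compound 2 gives 2400 nM; this single change produced a 3.7-fold lower number from compound 1 to compound 2 (0.57 log units; beyond the scatter).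

Compound 3, `CCN(CCCOc1ccc(C(=O)/C=C/c2ccccc2)c(O)c1)Cc1ccccc1N(C)C`, is built on a different core, and how that core differs from the core of compound 1 is not broken down here. In this assay compound 3 gives 800 nM, the lowest number of the three.

Compound 4, `CCN(CCCOc1ccc(C(=O)/C=C/c2ccc(N(C)C)cc2)c(O)c1)Cc1ccccc1N(C)C`, is made from compound 3 by the same kind of change seen between compound 1 and compound 2: dimethylamino in place of hydrogen on an aromatic carbon. Both changes put the group on an aromatic carbon of a six-membered aromatic ring of carbon only, para to a large group, though in one case the wider reading is benzyl to 4-(dimethylamino)benzyl and in the other 2-phenylethenyl to 2-(4-(dimethylamino)phenyl)ethenyl. Because compound 1 to compound 2 gave a 3.7-fold lower number from compound 1 to compound 2 (0.57 log units; beyond the scatter), a step of similar direction is expected here, a 2.3-fold lower number from compound 3 to compound 4 (0.36 log units; beyond the scatter), on a different core and so with wider uncertainty. Compound 4 is therefore estimated at 350 nM, with a likely range from 120 nM to 1000 nM.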

Compound 4, half-maximal inhibitory concentration: 3200 nM
Estimate against measurement, compound 4: 9.1-fold (0.96 log units) below, and the stated range ends below it.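

The same swap of hydrogen for dimethylamino on an aromatic carbon does not carry over in sign between these two cores. In this assay it gives a 4.0-fold higher number from compound 3 to compound 4 (0.60 log units; beyond the scatter), whereas the earlier step ran the other way, and the gap between the two steps is real rather than noise: the same change on two cores in this assay, a 3.7-fold lower number (0.57 log units; beyond the scatter) from compound 1 to compound 2 and a 4.0-fold higher number (0.60 log units; beyond the scatter) from compound 3 to compound 4, 15-fold (1.17 log units) apart, beyond the scatter of two such steps. This shows that a gain seen on one core cannot simply be assumed on another in this series, but it does not show why, since the two steps differ both in the surrounding core and in the group that changes, benzyl to 4-(dimethylamino)benzyl in one and 2-phenylethenyl to 2-(4-(dimethylamino)phenyl)ethenyl in the other.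

The compounds shown leave open which of these differences decides the direction of the step. They also leave open whether a simple amine or a methoxy group in the same place on the 2-phenylethenyl ring would raise the number as dimethylamino does.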